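The source may report more compounds than this note shows. Statements on the series, on what has been measured and on what is new or still open speak of the compounds shown alone.

Measured so far:
compound 1 `CNC(=O)c1cccnc1NCCCN1CCN(c2ccccc2OC)CC1` — 1 nM
compound 2 `CN(C)C(=O)c1cccnc1NCCCN1CCN(c2ccccc2O)CC1` — 5.01 nM

In a functional assay for antagonist activity at Alpha-1A adrenergic receptor (Oryctolagus cuniculus) (a lower number here means tighter binding, a higher number weaker binding), compound 1 gives 1 nM and compound 2 gives 5.01 nM; compound 2 holds the higher of the two numbers, beyond the scatter. Compound 3 `CN(C)C(=O)c1cccnc1NCCCN1CCN(c2ccccc2Cc2ccccc2)CC1` is the next compound. It differs from compound 2 by benzyl in place of hydroxy on an aromatic carbon. Going by the values given here, no comparable step has been measured, so the expectation rests only on compound 2. A small change in the weaker direction, or none beyond the scatter, is expected; the estimated step is a 2.0-fold higher number from compound 2 to compound 3 (0.30 log units; within the scatter). Compound 3 is expected to give 10 nM, within 2.5 nM to 40 nM.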

Compound 3, dissociation constant: 6.31 nM
Compound 3: the middle estimate sits 1.6-fold (0.20 log units) above what was measured, within the range that was stated.
By their numbers in this assay, from the lowest: compound 1; then compounds 2 and 3 (each within the scatter of the next).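

In this assay, benzyl in place of hydroxy on an aromatic carbon, ortho to a large group, gives a 1.3-fold higher number from compound 2 to compound 3 (0.10 log units; within the scatter). At this position, the step from hydroxy, with 1 hydrogen-bond donor and 1 hydrogen-bond acceptor, to benzyl, with neither, stays within the scatter despite the added six-membered aromatic ring. No measurement available here accounts for this result.

On these data alone, how an amine or a carboxylic acid on this aromatic carbon would compare with compound 2 and compound 3 remains open. So does whether a longer chain ending in the same aromatic ring would stay within the scatter of compound 3.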